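The compounds below may be only part of what the source reports. "The series", "measured", "known", "first", "only" and "open" are said of these compounds alone.

Working notes on the series. Compound 1 `COc1ccccc1Oc1ccc2c(NCCCNCc3ccco3)ccnc2c1` is measured in a physicochemical assay for solubility, with a stated time of 18 h, at pH 7.4 (on this read-out lower numbers stand for lower solubility and higher numbers for higher solubility), and gives 14500 nM. Compound 2 `COc1ccc(Oc2ccc3c(NCCCNCc4cc(F)ccc4OC)ccnc3c2)cc1` gives 14500 nM in this assay, so compound 1 stands level with compound 2 at the digits shown, within the scatter. Compound 3 `CC(C)Cc1ccc2c(NCCCNCc3ccco3)ccnc2c1` is not yet measured. It differs from compound 1 by isobutyl in place of 2-methoxyphenoxy on an aromatic carbon. Going by the values given here, no step between measured compounds is available for this kind of change, so the direction is open; the expected step from compound 1 to compound 3 in this assay is a 1.0-fold higher number from compound 1 to compound 3 (0.01 log units; within the scatter), which is not expected to exceed the scatter. For compound 3 the expected solubility is 15000 nM, with a range from 5000 nM to 45000 nM.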

Compound 3, solubility: 4200 nM
Estimate against measurement, compound 3: 3.6-fold (0.55 log units) above, and the stated range ends above it.
By their numbers in this assay, from the lowest: compound 3; then compounds 1 and 2 (each within the scatter of the next).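

Going by these compounds alone, the aromatic carbon carrying 2-methoxyphenoxy in compound 1 is not indifferent to its substituent: isobutyl there gives a 3.5-fold lower number from compound 1 to compound 3 (0.54 log units; beyond the scatter) in this assay, the first step beyond the scatter. The change removes the aromatic ring and both oxygen atoms of the group together. No measurement in hand accounts for the step.

One step cannot separate the contributions of the ring, the oxygen atoms and group size. From the compounds shown here alone, how an unsubstituted phenoxy, a longer alkyl chain or an amine at this carbon would compare also remains open.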